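This account rests on a few compounds, and the source may have more. Where it says the series, first, only, none or still open, it means among the compounds named here.

Of the compounds shown here, three share one core and have been tested in an assay on membranes from brain for binding affinity to adenosine receptor A1 (Rattus norvegicus), read by radioligand binding, tested at 20 uM; a lower number here means less inhibition, a higher number more inhibition at the concentration tested (going by the name of the read-out). Compound 1, `Cn1c(=O)[nH]c2c(cnn2-c2cccc([N+](=O)[O-])c2)c1=N`, carries a nitro group on its pendant aromatic ring; in this assay compound 1 gives 2%. Compound 2, `Cn1c(=O)[nH]c2c(cnn2-c2ccc(Cl)cc2Cl)c1=N`, carries two chloro groups on that ring, and in this assay compound 2 gives 9%, a number that lies within the usual scatter of the number for compound 1, so the two cannot be told apart. Compound 3, `CCCCn1c(=O)[nH]c2c(cnn2-c2cccc(Cl)c2)c1=N`, carries a butyl chain in place of the methyl and a single chloro group, and in this assay compound 3 gives 58%, well beyond the scatter above compound 1. Because compound 3 differs from compound 1 in more than one place, the data do not say which change carries that rise.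

Compound 4, `Cn1c(=O)[nH]c2c(cnn2-c2cccc(F)c2)c1=N`, keeps the methyl of compound 1 and differs from it in one place: fluoro in place of nitro on an aromatic carbon. Among the measured compounds shown here, no pair of measured compounds isolates a change of this kind, so the expectation rests on the nearness of compound 1 and compound 2 alone. The step from compound 1 to compound 4 is expected to be small, a number 8 percentage points higher from compound 1 to compound 4 (within the scatter), not beyond the scatter in either direction. In this assay compound 4 is estimated at 10%, with a likely range from 0% to 30%.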

Compound 4, a percentage reported as inhibition, at one concentration (the size of the read-out at that concentration, not a potency): 44%
Estimate against measurement, compound 4: 34 percentage points below; measured number outside the range, above it.
By their numbers in this assay, from the lowest: compounds 1 and 2 (each within the scatter of the next); then compound 4; then compound 3.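

In this assay, fluoro in place of nitro on an aromatic carbon gives a number 42 percentage points higher from compound 1 to compound 4 (beyond the scatter), so with the methyl and the rest of the shared core unchanged, the group at this place on the pendant ring, meta to a large group, can by itself move the number beyond the scatter. The earlier compounds shown here could not show this, since none of them formed a pair differing in one place, and the rise at compound 3 could not be tied to a single change. The step replaces a nitro of three heavy atoms, with two hydrogen-bond acceptors, by a single fluorine, but no measured property at hand accounts for it.

The compounds shown leave open where other groups at this place, such as an amine, a carboxylic acid or a methoxy group, would fall relative to nitro and fluoro. They also leave open whether fluoro in place of nitro gives a step of like size when a butyl chain stands in place of the methyl, and how a single chloro group compares with fluoro when the methyl is kept.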